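The source may hold more compounds than are shown below. What is called first, only, known or untested is meant among the compounds shown, and "the series" means these compounds.

Compound 3 `Nc1scc(CN2CCN(c3ccccc3C(F)(F)F)CC2)c1C(=O)c1ccc(Cl)cc1` gives 0% in a functional assay on CHO cells with adenosine receptor A1 (Homo sapiens) as the target, read by cAMP accumulation and immunoassay, with a stated time of 6 min, tested at 0.01 uM (a lower number here means a stronger effect, a higher number a weaker effect of the compound at the concentration tested), the highest of the three numbers measured, although not all are separated beyond the scatter. Compound 1 `Nc1scc(CN2CCN(c3ccc(Cl)cc3F)CC2)c1C(=O)c1ccc(Cl)cc1` gives -9.2%, within the scatter of compound 3; compound 2 `Nc1scc(CN2CCN(c3ccc([N+](=O)[O-])cc3)CC2)c1C(=O)c1ccc(Cl)cc1` gives -12%, and the step of a number 12 percentage points higher from compound 2 to compound 3 (beyond the scatter) is the only one beyond the scatter. Compound 4 `Nc1scc(CN2CCN(c3cccc(F)c3)CC2)c1C(=O)c1ccc(Cl)cc1` differs from compound 3 in one place: 3-fluorophenyl in place of 2-(trifluoromethyl)phenyl on an amine nitrogen in a ring. Earlier swaps of the group on the same ring nitrogen moved this assay little: a number 2.8 percentage points lower from compound 1 to compound 2 (within the scatter) and a number 9.2 percentage points higher from compound 1 to compound 3 (within the scatter), with a number 12 percentage points higher from compound 2 to compound 3 (beyond the scatter) modest. Another such swap is therefore expected to shift compound 4 by a number 4 percentage points lower from compound 3 to compound 4 (within the scatter), a step not expected to exceed the scatter. Compound 4 is estimated at -4%, within a range from -18% to 10%.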

Compound 4, a percentage reported as activity, at one concentration (the size of the read-out at that concentration, not a potency): -18%
Compound 4: middle estimate off by 14 percentage points, on the high side; low and high end bracket the measured number.
By their numbers in this assay, from the lowest: compounds 4, 2, 1 and 3 (each within the scatter of the next, the first and the last beyond it).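

In this assay, replacing 2-(trifluoromethyl)phenyl with 3-fluorophenyl on the ring nitrogen gives a second step beyond the scatter at this position, a number 18 percentage points lower from compound 3 to compound 4 (beyond the scatter), so compound 3 is now separated from two of the three other compounds. The other two steps, a number 6 percentage points lower from compound 2 to compound 4 (within the scatter) and a number 8.8 percentage points lower from compound 1 to compound 4 (within the scatter), stay within the scatter, so compound 4 cannot be told apart from those two compounds. No evidence is available to explain these differences.

Open, from the compounds shown here alone, is how a phenyl ring carrying an amine or a carboxylic acid would read on this nitrogen. These results also cannot show how the compounds compare at other concentrations.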